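Compound 3 to compound 4: a smaller amine group

This account rests on a few compounds, and the source may have more. Where it says the series, first, only, none or still open, it means among the compounds named here.

Measured in a functional assay on HCT-116 cells (Homo sapiens) for cytotoxicity, read by MTT assay, with a stated time of 72 h; a higher number here means a weaker inhibitor, a lower number a stronger inhibitor:
- compound 1 `O=C(NCc1ccc(F)cc1)c1nc(NCCO)c2cccnc2c1O`: "not determined" (no result reported)
- compound 2 `O=C(NCc1ccc(F)cc1)c1nc(Br)c2cccnc2c1NCCCNc1c(C(=O)NCc2ccc(F)cc2)nc(Br)c2cccnc12`: > 20000 nM
- compound 3 `O=C(NCc1ccc(F)cc1)c1nc(Br)c2cccnc2c1NCc1ccc(F)cc1`: > 20000 nM

Compound 3 gives > 20000 nM, which is a limit and not a number. Compound 2 gives > 20000 nM, also a limit. Compound 1 has no number to compare: "not determined" (no result reported). Among the measured compounds shown here, the series therefore offers the limit of > 20000 nM in this assay, at which 2 of the 3 values shown sit, and no measured step, so the position of compound 3 is known only as a limit.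

The next structure is compound 4 `CNc1c(C(=O)NCc2ccc(F)cc2)nc(Br)c2cccnc12`. In it, hydrogen stands in place of 4-fluorophenyl on a saturated chain carbon bound to a nitrogen on an aromatic ring, which turns 4-fluorobenzyl into methyl and (4-fluorobenzyl)amino into methylamino: hydrogen in place of 4-fluorophenyl on a saturated chain carbon bound to a nitrogen on an aromatic ring.

No change beyond the scatter is expected in this assay, and no direction can be assigned with any confidence. This expectation rests on compound 3 , whose limit is > 20000 nM. The expected move is a number no higher from compound 3 to compound 4 (the limit leaves the size open), and a further report of only a limit is the likeliest outcome. Compound 4 is estimated at 20000 nM, with an expected range of 7000 nM to 40000 nM.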

Compound 4, half-maximal inhibitory concentration: > 20000 nM
Compound 4: only a limit was reported; the forecaster's own chance of this, stated with the estimate: 70%; the middle value lies on the limit itself.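

In this assay compound 4 gives > 20000 nM, a limit and not a number. Compound 3 also has only a limit, so no new step can be read between compound 3 and compound 4, and the series stays at one value: the limit of > 20000 nM in this assay, at which 3 of the 4 values shown sit.

The compounds shown leave open whether changing 4-fluorobenzyl to methyl alters cytotoxicity at all.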